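Swapping the bicyclic ketone for an oxygen-bridged ring

The compounds below may be only part of what the source reports. "The series", "measured", "known", "first", "only" and "open" are said of these compounds alone.

Compound 2 `O=C1CC2CC(Nc3ncnc4c3ncn4C[C@@H]3O[C@H](CO)[C@@H](O)[C@H]3O)C1C2` gives 2.7 nM in a functional assay on MF-2 cells (Cricetulus griseus) for agonist activity at adenosine receptor A1 (Homo sapiens), read by cAMP accumulation (a lower number here means that less compound is needed, a higher number that more compound is needed for the effect), the lowest of the two numbers measured here. Compound 1 `OC[C@H]1O[C@@H](Cn2cnc3c(NC4CC5CC4CC5O)ncnc32)[C@H](O)[C@@H]1O` gives 8 nM, and the step of a 3.0-fold lower number from compound 1 to compound 2 (0.47 log units; beyond the scatter). Compound 3 `OC[C@H]1O[C@@H](Cn2cnc3c(NC4CC5CCC4O5)ncnc32)[C@H](O)[C@@H]1O` carries a group of 7 heavy atoms (6 carbon, 1 oxygen; 2 five-membered non-aromatic rings with 1 hetero atom each) in place of a group of 8 heavy atoms (7 carbon, 1 oxygen; 2 five-membered non-aromatic rings of carbon only), on a nitrogen on an aromatic ring. Among the measured compounds shown here, the only measured step altered a different part of this group, so it bears on the new change only loosely; a shift of modest size in either direction, or none beyond the scatter, seems most likely. The expected step is a 1.9-fold higher number from compound 2 to compound 3 (0.27 log units; within the scatter). Compound 3 is estimated at 5 nM, between 1.5 nM and 16 nM.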

Compound 3, half-maximal effective concentration: 7.1 nM
For compound 3 the middle estimate is 1.4-fold (0.15 log units) below the measured one; low and high end bracket the measured number.
By their numbers in this assay, from the lowest: compound 2; then compounds 3 and 1 (each within the scatter of the next).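

In this assay, the oxygen-bridged group does not keep what the ketone of compound 2 gives, with a 2.6-fold higher number from compound 2 to compound 3 (0.42 log units; beyond the scatter). Measured against the hydroxyl-bearing compound 1, the same group shows no real difference, with a 1.1-fold lower number from compound 1 to compound 3 (0.05 log units; within the scatter), so among these three groups on the nitrogen only the ketone stands apart. No supporting data here explain this result.

Going by these compounds, it remains open whether the ketone itself or the carbon-only ring frame around it matters more. An amine in place of the ketone could help to separate these two possibilities.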